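The compounds below may be only part of what the source reports. "The series", "measured", "known", "first", "only" and "open" are said of these compounds alone.

Measured so far:
- compound 1 `COc1ccc(-c2cc(/C=C/C(=O)c3ccc(OC)c(OC)c3)nc3cc(-c4ccccc4)nn23)cc1` — 8700 nM
- compound 2 `COc1cc(-c2cc(/C=C/C(=O)c3ccccc3)nc3cc(-c4ccccc4)nn23)cc(OC)c1OC` — 15800 nM
- compound 3 `COc1ccc(C(=O)/C=C/c2cc(-c3ccc(OC)cc3)n3nc(-c4ccccc4)cc3n2)cc1` — 6300 nM

All three compounds share one core and were tested in a functional assay on MDA-MB-231 cells (Homo sapiens) for antiproliferative activity, read by MTT assay, with a stated time of 24 h; a lower number here means a stronger inhibitor, a higher number a weaker inhibitor. Compound 3 gives the lowest of the three numbers, but its gap to compound 1 is within the scatter, so the two cannot be told apart; only compound 2 stands clearly apart, with a number beyond the scatter above compound 3.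

The next compound, compound 4 `COc1ccc(-c2cc(/C=C/C(=O)c3ccccc3)nc3cc(-c4ccccc4)nn23)cc1`, is derived from compound 3 by one change: hydrogen in place of methoxy on an aromatic carbon. Within the data shown here, the one measured step that speaks to this change is the removal of a methoxy on the same carbonyl-bearing ring, a 1.4-fold lower number from compound 1 to compound 3 (0.14 log units; within the scatter), which stayed within the scatter. Among the measured compounds shown here, there is no measured step for taking away the last methoxy on that ring, so the expectation leans on that single comparison and carries wide uncertainty; compound 2, with a plain benzoyl but a differently substituted other ring, gives a higher number, yet it differs from compound 4 in more than one place and supplies no direct step.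

On this basis compound 4 is expected to come out close to compound 3, with a step of a 1.2-fold higher number from compound 3 to compound 4 (0.08 log units; within the scatter) in this assay, and an estimated value of 7500 nM within the range 3500 nM to 17000 nM.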

Compound 4, half-maximal inhibitory concentration: 9900 nM
Estimate against measurement, compound 4: 1.3-fold (0.12 log units) below; low and high end bracket the measured number.
By their numbers in this assay, from the lowest: compounds 3, 1, 4 and 2 (each within the scatter of the next, the first and the last beyond it).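

Replacing the (4-methoxyphenyl)carbonyl of compound 3 with a plain benzoyl gives a 1.6-fold higher number from compound 3 to compound 4 (0.20 log units; within the scatter) in this assay, so this carbon can carry hydrogen instead of methoxy with no difference that can be told from the scatter. The fully bare benzoyl now also has a direct comparison with a richer substitution at the same place, phenyl in place of 3,4-dimethoxyphenyl on the carbonyl carbon, which gives a 1.1-fold higher number from compound 1 to compound 4 (0.06 log units; within the scatter), while on the other aryl group, 4-methoxyphenyl in place of 3,4,5-trimethoxyphenyl gives a 1.6-fold lower number from compound 2 to compound 4 (0.20 log units; within the scatter), and neither change can be told from the scatter either. Nothing is available here that would explain these numbers.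

Methoxy and hydrogen are the only groups compared at this carbon, so it stays open whether an amine, a carboxylic acid or a longer chain such as butoxy would shift the number beyond the scatter. As far as these compounds go, the phenyl on the shared core stays the same in all four compounds, so what a change there, for example to a pyridine ring, would do also remains unknown.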